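A few compounds are considered here, and "the series" means these few. Any claim that something is new, unique, unknown or untested is made for them only; others in the source may bear on it.

Among the measured compounds shown here, compound 3 `NC(=O)c1ccc(NC(=O)c2cn(Cc3c(F)cccc3Cl)c3ccc(=O)[nH]c3c2=O)cc1` stands lowest of the three numbers so far in an in vitro assay on Sf21 cells for inhibition of high affinity 3',5'-cyclic-AMP phosphodiesterase 7A (Homo sapiens), read by scintillation proximity assay, with a stated time of 30 min (on this read-out lower numbers stand for stronger inhibition and higher numbers for weaker inhibition), where compound 3 gives 10 nM. Its nearest neighbour is compound 2 `CC(=O)c1ccc(NC(=O)c2cn(Cc3c(F)cccc3Cl)c3ccc(=O)[nH]c3c2=O)cc1`, which in this assay gives 18 nM; the step of a 1.8-fold lower number from compound 2 to compound 3 (0.26 log units; within the scatter) lies within the scatter, so the two cannot be ranked. Compound 1 `CN(C)c1ccc(NC(=O)c2cn(Cc3c(F)cccc3Cl)c3ccc(=O)[nH]c3c2=O)cc1` is the furthest away, giving 39 nM in this assay; the steps of a 2.2-fold lower number from compound 1 to compound 2 (0.34 log units; beyond the scatter) and a 3.9-fold lower number from compound 1 to compound 3 (0.59 log units; beyond the scatter) both lie beyond the scatter, though each is modest.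

Compound 4 `NC(=O)c1cccc(NC(=O)c2cn(Cc3c(F)cccc3Cl)c3ccc(=O)[nH]c3c2=O)c1` differs from compound 3 in that (3-carbamoylphenyl in place of 4-carbamoylphenyl on an amide-type nitrogen). For the measured compounds named here, none of the measured steps tests a change of this kind: all three exchange one group for another on an aromatic carbon, and none exchanges one carbamoylphenyl for the other. What the measured steps do show is that alterations to this part of the molecule shifted the numbers in this assay by modest amounts only. On that basis the step of a 2.5-fold higher number from compound 3 to compound 4 (0.40 log units; beyond the scatter) is expected to be modest, leaning toward a higher number, and it may well fall within the scatter. Compound 4 is accordingly estimated at 25 nM in this assay, with a range from 8 nM to 80 nM.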

Compound 4, half-maximal inhibitory concentration: 44 nM
Compound 4: the middle estimate sits 1.8-fold (0.25 log units) below what was measured; the measured number falls inside the stated range.
By their numbers in this assay, from the lowest: compounds 3 and 2 (each within the scatter of the next); then compounds 1 and 4 (each within the scatter of the next).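

Swapping 4-carbamoylphenyl for 3-carbamoylphenyl on the amide-type nitrogen keeps the same atoms and joins them differently, yet in this assay it gives a 4.4-fold higher number from compound 3 to compound 4 (0.64 log units; beyond the scatter) and so shows that where the carbamoyl group sits on this ring matters, not only which group is present. The earlier steps shown here exchanged one group for another and could not show this, and the change of place here is as large as any step measured at this position. The 3-carbamoylphenyl compound also stands apart from the acetyl compound, with a 2.4-fold higher number from compound 2 to compound 4 (0.39 log units; beyond the scatter) as the step, but it cannot be ranked against the dimethylamino compound, with a 1.1-fold higher number from compound 1 to compound 4 (0.05 log units; within the scatter) as the step, and nothing available explains the effect of moving the group.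

The compounds shown leave open whether 3-acetylphenyl would differ from 4-acetylphenyl in the same way, since the effect of place is seen for the carbamoyl group alone. They also leave open how 2-carbamoylphenyl, 4-carboxyphenyl or 4-(aminomethyl)phenyl would stand against 4-carbamoylphenyl on this nitrogen.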